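The compounds below may be only part of what the source reports. "The series", "measured", "known", "first", "only" and "open" are said of these compounds alone.

Compound 1 `Oc1cccc(-c2nc(N3CCCCC3)c3nc[nH]c3n2)c1` was tested in an assay on cells for displacement of a labelled ligand from adenosine receptor A1 (Homo sapiens), read by scintillation counting and radioligand binding, with a stated time of 60 min, tested at 10 uM; on this read-out higher numbers stand for more inhibition at the one concentration tested (going by the name of the read-out) and lower numbers for less inhibition. In this assay compound 1 sits at the upper limit, > 80%, which is a limit of the assay rather than a number, the situation described as the limit of > 80% in this assay, at which 1 of the 2 values shown sits. A close relative, compound 2 `Cn1cnc2c(N3CCCCC3)nc(-c3cccc(O)c3)nc21`, carries a methyl in place of hydrogen on an aromatic nitrogen of the shared core, and in this assay compound 2 gives 78.5%. The step of a number at least 1.5 percentage points lower from compound 1 to compound 2 (that floor lies within the scatter) lies within the usual scatter of repeated measurements. Compound 3 `Oc1ccc(-c2nc(N3CCCCC3)c3nc[nH]c3n2)cc1` differs from compound 1 in another way: 4-hydroxyphenyl in place of 3-hydroxyphenyl on an aromatic carbon. No measured step touches a change of this kind, so nothing shown tells its size or direction. Both measured compounds inhibit strongly, so compound 3 is expected to remain in a similar region, with some room for loss. The expected step is a number at least 10 percentage points lower from compound 1 to compound 3 (that floor lies within the scatter). The estimate for compound 3 is 70%, with a range from 40% to 85%.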

Compound 3, a percentage reported as inhibition, at one concentration (the size of the read-out at that concentration, not a potency): > 80%
Compound 3 ended at the assay's limit; the forecaster's own chance of this, stated with the estimate: 30%; middle value at least 10 percentage points away from the limit.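

Compound 1 and compound 3 both sit at a limit of this assay rather than at a number, so no step can be read between them: the limit of > 80% in this assay, at which 2 of the 3 values shown sit. Going by these compounds, whether 4-hydroxyphenyl in place of 3-hydroxyphenyl changes inhibition at all, and in which direction, stays open.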